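Benzyl ether at the oxygen of the shared core

This account rests on a few compounds, and the source may have more. Where it says the series, first, only, none or still open, it means among the compounds named here.

Measured so far:
compound 1, `CO[C@H]1CC[C@H]2CCN(C)[C@H]2C1`, 300000 nM in an assay on HEK293 cells for displacement of a labelled ligand from Neuronal acetylcholine receptor; alpha4/beta2 (Rattus norvegicus), with a stated time of 4 h; a lower number here means a stronger inhibitor, a higher number a weaker inhibitor
compound 2, `CCO[C@H]1CC[C@H]2CCN(C)[C@H]2C1`, 300000 nM in this assay

Compound 2 stands level with compound 1: the step of no change at the digits printed from compound 1 to compound 2 (within the scatter) was flat. Compound 3, `CN1CC[C@@H]2CC[C@H](OCc3ccccc3)C[C@@H]21`, differs from compound 2 by phenyl in place of methyl on a saturated chain carbon bound to an oxygen on a saturated carbon. Going by the values given here, no measured step tests a phenyl at this place; the only known step at this oxygen, no change at the digits printed from compound 1 to compound 2 (within the scatter), was a small change in size and gave nothing. For compound 3 the expectation is therefore a weak binder like compound 2, with wide uncertainty, estimated at 200000 nM (range 30000 nM to 1000000 nM), a step of a 1.5-fold lower number from compound 2 to compound 3 (0.18 log units; within the scatter) from compound 2.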

Compound 3, inhibition constant: 100000 nM
For compound 3 the middle estimate is 2.0-fold (0.30 log units) above the measured one; low and high end bracket the measured number.
By their numbers in this assay, from the lowest: compound 3; then compounds 1 and 2 (each within the scatter of the next).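

At this oxygen the group can matter in this assay: phenyl in place of methyl gives a 3.0-fold lower number from compound 2 to compound 3 (0.48 log units; beyond the scatter) and phenyl in place of hydrogen gives a 3.0-fold lower number from compound 1 to compound 3 (0.48 log units; beyond the scatter) on a saturated chain carbon bound to an oxygen on a saturated carbon. Going by these compounds alone, the earlier change from compound 1 to compound 2 was flat, so the larger group is the first to move the number, though only modestly. No evidence here explains this shift.

From the compounds shown here alone, whether a longer chain, an amine or a carboxylic acid in place of the phenyl would lower the number further remains open.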